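A few compounds are considered here, and "the series" means these few. Any claim that something is new, unique, unknown or untested is made for them only; others in the source may bear on it.

Compound 1 `CCN(CC)c1ccc2cc(C(=O)c3ccc(N4CCN(C(=O)CN5CCN(C(=O)/C=C/c6ccccc6)CC5)CC4)cc3)oc2c1` gives 1140 nM in a functional assay on SGC-7901 cells (Homo sapiens) for cytotoxicity, read by MTT assay, with a stated time of 48 h; a higher number here means a weaker inhibitor, a lower number a stronger inhibitor.
Compound 2 `CCN(CC)c1ccc2cc(C(=O)c3ccc(N4CCN(C(=O)CN5CCN(S(=O)(=O)C6CC6)CC5)CC4)cc3)oc2c1` gives 15300 nM in this assay.
Compound 3 `CCN(CC)c1ccc2cc(C(=O)c3ccc(N4CCN(C(=O)CN5CCN(Cc6ccc(/C=C/C(=O)OC)cc6)CC5)CC4)cc3)oc2c1` gives 740 nM in this assay.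

Compound 3 has the lowest number of the three; compound 1 sits within the scatter of it, while compound 2 lies well beyond it. Compound 4 `CCOC(=O)CN1CCN(CC(=O)N2CCN(c3ccc(C(=O)c4cc5ccc(N(CC)CC)cc5o4)cc3)CC2)CC1` differs from compound 3 by ethoxycarbonyl in place of 4-(2-(methoxycarbonyl)ethenyl)phenyl on a saturated chain carbon bound to an amine nitrogen in a ring. Within the data shown here, the one measured step that bears on this is a 13-fold higher number from compound 1 to compound 2 (1.13 log units; beyond the scatter), where a small group replaced a larger one carrying an aromatic ring on an amine nitrogen in a ring. The change from compound 3 to compound 4 likewise trades a group with an aromatic ring for a small one, so a weakening beyond the scatter is expected, though its size is uncertain. Compound 4 is expected at 5000 nM, between 1500 nM and 20000 nM, a step of a 6.8-fold higher number from compound 3 to compound 4 (0.83 log units; beyond the scatter).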

Compound 4, half-maximal inhibitory concentration: > 40000 nM
Compound 4: a limit, no number; the forecaster's own chance of this, stated with the estimate: 5%; middle value at least 8.0-fold (0.90 log units) away from the limit.
By their numbers in this assay, from the lowest: compounds 3 and 1 (each within the scatter of the next); then compound 2. At a limit, above all of these: compound 4.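

In this assay compound 4 reaches only a limit, > 40000 nM, and not a number. Putting ethoxycarbonyl in place of 4-(2-(methoxycarbonyl)ethenyl)phenyl gives an at least 54-fold higher number from compound 3 to compound 4 (1.73 log units; beyond the scatter), so the carbonyl-bearing ester end alone does not keep the activity. The (ethoxycarbonyl)methyl group also gives an at least 35-fold higher number from compound 1 to compound 4 (1.54 log units; beyond the scatter) and an at least 2.6-fold higher number from compound 2 to compound 4 (0.41 log units; beyond the scatter), so it falls behind even cyclopropylsulfonyl.

The compounds shown leave open whether the aromatic ring itself or simply the size of the group counts. A plain benzyl group or a long saturated chain at this place would separate the two.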